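The source may hold more compounds than are shown below. What is called first, only, known or untested is meant among the compounds shown, and "the series" means these compounds.

Compound 1 `O=[N+]([O-])c1cn2c(n1)SCC(OCc1ccc(-c3ccc(OC(F)(F)F)cc3)cn1)C2` gives 21000 nM in an ADME assay on MRC5 cells (Homo sapiens) for cytotoxicity; a higher number here means a weaker inhibitor, a lower number a stronger inhibitor. Compound 3 `O=[N+]([O-])c1cn2c(n1)[S+]([O-])CC(OCc1ccc(OC(F)(F)F)cc1)C2` gives 60000 nM; > 64000 nM (2 entries) in this assay. Compound 2 `O=[N+]([O-])c1cn2c(n1)[S@@+]([O-])C[C@@H](OCc1ccc(OC(F)(F)F)cc1)C2` gives only a limit of the assay in this assay, > 64000 nM, so no single number is known for it. Compound 4 `O=[N+]([O-])c1cn2c(n1)[S@+]([O-])C[C@H](OCc1ccc(OC(F)(F)F)cc1)C2` keeps every atom and bond of compound 2 and differs only in configuration: the two compounds have the same atoms and bonds and differ only in configuration as drawn: 2 of 2 stereo elements differ (all stereocentres are inverted: mirror images); a stereocentre at a sulfur is drawn S in compound 2 and R in compound 4; a stereocentre at a saturated ring carbon is drawn S in compound 2 and R in compound 4. Going by the values given here, no measured step of this kind is available here. The expected step in this assay is none beyond the scatter, given that compound 3, drawn without configuration where compound 2 is drawn with one (the fact that one of compounds 2 and 3 is drawn with a defined configuration and the other without, at the place where they differ), sits at or close to the limit (the several entries of compound 3 in this assay, 60000 nM; > 64000 nM (2 entries)). Compound 4 is therefore expected at 60000 nM, between 30000 nM and 120000 nM, which means a step of an at least 1.0-fold lower number from compound 2 to compound 4 (0.02 log units; that floor lies within the scatter).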

Compound 4, half-maximal inhibitory concentration: > 64000 nM
Compound 4 gave a limit, no number; the forecaster's own chance of this, stated with the estimate: 50%; at least 1.0-fold (0.02 log units) between middle value and limit.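

Going by these compounds alone, compound 2 and compound 4 both give only a limit of the assay, so no step between these two mirror images can be read. From the compounds shown here alone, whether their configurations differ at all in this assay stays open.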